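The compounds below may be only part of what the source reports. "The series", "measured", "known", "first", "only" and "open" are said of these compounds alone.

Measured compounds in a functional assay on MCF7 cells (Homo sapiens) for cytotoxicity, read by MTT assay, with a stated time of 72 h; a higher number here means a weaker inhibitor, a lower number a stronger inhibitor:
compound 1 `COc1ccc(/C=C2\S/C(=N\c3csc(-c4ccc(Cl)cc4)c3)NC2=O)cc1` gives 1000 nM
compound 2 `Cc1ccc(/C=C2\S/C(=N\c3csc(-c4ccc(Cl)cc4)c3)NC2=O)cc1` gives 900 nM
compound 3 `Cc1ccc(/C=C2\S/C(=N\c3nc(-c4ccc(Cl)cc4)cs3)NC2=O)cc1` gives 400 nM

Compound 3 has the lowest of the three numbers; its nearest neighbour is compound 2, whose value stands beyond the scatter from it, and compound 1 is the furthest. Among the compounds with values here, the difference between the core of compound 2 and the core of compound 3 is not broken down here; the two values show only that compound 3 sits lower.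

Within the core of compound 1 and compound 2 one change is measured: methoxy in place of methyl on an aromatic carbon It gave a 1.1-fold higher number from compound 2 to compound 1 (0.05 log units; within the scatter) The same change is now applied to compound 3, giving compound 4 `COc1ccc(/C=C2\S/C(=N\c3nc(-c4ccc(Cl)cc4)cs3)NC2=O)cc1`: methoxy in place of methyl on an aromatic carbon The place is described in the same words for both pairs, so this is taken as the same change on a different core.

Because the earlier step of a 1.1-fold higher number from compound 2 to compound 1 (0.05 log units; within the scatter) stayed within the scatter, the step from compound 3 to compound 4 is expected to be of similar size, a 1.1-fold higher number from compound 3 to compound 4 (0.05 log units; within the scatter), with the core difference adding no known reason to expect otherwise. In this assay compound 4 is therefore estimated at 450 nM, with a range from 250 nM to 800 nM.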

Compound 4, half-maximal inhibitory concentration: 100 nM
Estimate against measurement, compound 4: 4.5-fold (0.65 log units) above; the measured number lies below the stated range.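

Methoxy in place of methyl on an aromatic carbon, the change from 4-methylphenyl to 4-methoxyphenyl, gives a 4.0-fold lower number from compound 3 to compound 4 (0.60 log units; beyond the scatter) in this assay, and this step does not match the one measured on the other core: the same change on two cores in this assay, a 1.1-fold higher number (0.05 log units; within the scatter) from compound 2 to compound 1 and a 4.0-fold lower number (0.60 log units; beyond the scatter) from compound 3 to compound 4, 4.4-fold (0.65 log units) apart, beyond the scatter of two such steps.

Within the data shown here, in this series the change therefore cannot be carried from one core to the other at a fixed size, and a step within the scatter on one core is no guide to the step on the other. The result rests on a single pair for each core, so it does not show why the two cores respond differently, nor whether the larger step would hold for other compounds built on the core of compound 3.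

The compounds shown leave open whether other groups at this place, such as a hydroxyl, an amine or a longer alkoxy chain, would split between the two cores in the same way. Also open, as far as these compounds go, is whether the gap would persist with a carboxylic acid in place of the chlorine.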